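Quinoline thiosemicarbazones: cyano to hydrogen on the phenyl

The source may report more compounds than this note shows. Statements on the series, on what has been measured and on what is new or still open speak of the compounds shown alone.

Of the compounds shown here, three of this set have been tested in a functional assay on SGC-7901 cells (Homo sapiens) for antiproliferative activity, read by sulforhodamine B assay, with a stated time of 72 h; a higher number here means a weaker inhibitor, a lower number a stronger inhibitor. Compound 1 `NC(=S)N/N=C/c1cc2ccccc2s1` carries the unsubstituted thiocarbamoyl end on a different core; in this assay compound 1 gives only a limit of the assay, > 100000 nM. Compound 3 `Cc1ccc(NC(=O)N/N=C/c2ccc3ccccc3n2)cc1` is the urea analogue with a tolyl group; in this assay compound 3 likewise gives only a limit, > 100000 nM. For the measured compounds named here, compound 2 `N#Cc1ccc(NC(=S)N/N=C/c2ccc3ccccc3n2)cc1` is the one member with a numerical result: in this assay compound 2 gives 23700 nM. It therefore stands as the only number shown, against (the limit of > 100000 nM in this assay, at which 2 of the 3 values shown sit).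

Compound 4 `S=C(N/N=C/c1ccc2ccccc2n1)Nc1ccccc1` is the next member, with the change (hydrogen in place of cyano on an aromatic carbon). The two compounds share the thiosemicarbazone and the quinoline aldehyde part; only the phenyl substitution differs. Going by the values given here, no step between measured compounds bears on this change, so the weight of the cyano group cannot be read from the data in hand. With compound 2 as the one anchor and two limits around it, the expectation for compound 4 is a modest loss, with a fair chance that only a limit is returned; the expected step of a 1.7-fold higher number from compound 2 to compound 4 (0.23 log units; within the scatter) leans toward a weaker inhibitor, though it could fall within the scatter. Compound 4 is estimated at 40000 nM, with a range from 10000 nM to 150000 nM.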

Compound 4, half-maximal inhibitory concentration: 26500 nM
Compound 4: the middle estimate sits 1.5-fold (0.18 log units) above what was measured, and the stated range covers the measured number.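

In this assay the series now has its first readable step at this position: a 1.1-fold higher number from compound 2 to compound 4 (0.05 log units; within the scatter). Cyano and hydrogen on this aromatic carbon, para to a large group, therefore cannot be told apart in this assay, and the numerical result of compound 2 does not depend on the nitrile being present, since compound 4, with an unsubstituted phenyl, also returns a number rather than a limit. No measured property among the data on hand accounts for this outcome, so the result stands as an observation on one pair only.

From the compounds shown here alone, whether the same tolerance extends to other groups at this place, such as an amine, a carboxylic acid or a methoxy group, remains open, as does the effect of a longer chain between the phenyl and the thiosemicarbazone nitrogen. Compound 1 and compound 3 each differ from compound 4 in more than one place, so the weight of the core, of the terminal phenyl and of the sulfur against the carbonyl oxygen cannot be read from them as single changes.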